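Alkynyl-pyridine amides: efficacy and a new amide substituent

The source may hold more compounds than are shown below. What is called first, only, known or untested is meant among the compounds shown, and "the series" means these compounds.

Measured so far:
- compound 1, `Cc1cc(C#Cc2cccc(F)c2)cnc1C(=O)N[C@H](C)C(C)(C)O`: 66.4%
- compound 2, `C[C@@H](NC(=O)c1ncc(C#Cc2cccc(F)c2)cn1)C(C)(C)O`: 64.1%
- compound 3, `C[C@H](NC(=O)c1ccc(C#Cc2cccc(F)c2)cn1)C(C)(C)C`: 70.8%

All three values come from a functional assay on HEK293 cells for positive allosteric modulation of metabotropic glutamate receptor 5 (Rattus norvegicus), read by fluorescence and calcium flux; a higher number here means a larger maximal response, a lower number a smaller maximal response. Compound 3 carries the highest of the three numbers, but its distance to compound 1 and to compound 2 lies within the scatter, so the three compounds cannot be placed in an order on these data; they read as one cluster of similar maximal response. The shared core with its alkyne is kept across the set, and the variation sits on the amide-type nitrogen.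

Compound 4, `O=C(NCC1CCC1)c1ccc(C#Cc2cccc(F)c2)cn1`, is not yet measured. It differs from compound 3 in one place: cyclobutylmethyl in place of 1,2,2-trimethylpropyl on an amide-type nitrogen. For the measured compounds named here, both groups are saturated carbon substituents of similar size on the amide-type nitrogen, and nothing among the measured compounds shows that such a swap moves the maximal response.

The expectation is therefore that compound 4 gives a maximal response close to that of compound 3, with a step of a number 4.8 percentage points lower from compound 3 to compound 4 (within the scatter) of no more than the scatter in either direction. The estimated value for compound 4 is 66%, with a range from 52% to 80%.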

Compound 4, largest response reached (reported as efficacy), in percent of the reference or control that the assay uses: 68.1%
Compound 4: the middle estimate sits 2.1 percentage points below what was measured, within the range that was stated.
By their numbers in this assay, from the lowest: compounds 2, 1, 4 and 3 (each within the scatter of the next).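

In this assay, for the compounds shown here, the one pair differing in a single place gives a number 2.7 percentage points lower from compound 3 to compound 4 (within the scatter) with cyclobutylmethyl in place of 1,2,2-trimethylpropyl on the amide-type nitrogen, so this change leaves the maximal response unmoved within the scatter. The same change removes the defined stereocentre and brings in a four-membered non-aromatic ring of carbon only, and neither feature separates the two compounds in this read-out. Nothing measured here bears on why the response holds across this swap.

On these data alone, whether the response also holds with a longer chain, an aminoethyl group or a carboxylic acid on this nitrogen remains open. Going by these compounds alone, compound 1 and compound 2 differ from the other compounds in more than one place, so no step involving either of them can be read.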